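A few compounds are considered here, and "the series" means these few. Any claim that something is new, unique, unknown or untested is made for them only; others in the source may bear on it.

Compound 1 `COc1c(N2CC(C)NC(C)C2)c(F)cc2c(=O)c(C(=O)O)cn(C3CC3)c12`, compound 2 `CC1CN(c2c(F)cc3c(=O)c(C(=O)O)cn(C4CC4)c3c2C(F)(F)F)CC(C)N1` and compound 3 `COc1c(N2CCCC(N)C2)c(F)cc2c(=O)c(C(=O)O)cn(C3CC3)c12` were examined in a functional assay on V79 cells (Cricetulus griseus) for cytotoxicity, read by colony formation; on this read-out higher numbers stand for weaker inhibition and lower numbers for stronger inhibition. Compound 1 reached only a limit there, > 500 ug/mL. Compound 2 likewise gave only a limit, > 500 ug/mL. Going by the values given here, compound 3 gave 69 ug/mL, the single number among the three. The difference between the two cores, (3-aminopiperidin-1-yl in place of 3,5-dimethylpiperazin-1-yl on an aromatic carbon), made an at least 7.2-fold lower number from compound 1 to compound 3 (0.86 log units; beyond the scatter) in this assay. The change trifluoromethyl in place of methoxy on an aromatic carbon made a step that the two limits leave unreadable from compound 1 to compound 2, because of the limit of > 500 ug/mL in this assay, at which 2 of the 3 values shown sit. Compound 4 `NC1CCCN(c2c(F)cc3c(=O)c(C(=O)O)cn(C4CC4)c3c2C(F)(F)F)C1`, not yet measured, differs from compound 3 by trifluoromethyl in place of methoxy on an aromatic carbon, the same kind of change, though here it sits ortho to a 3-aminopiperidin-1-yl group rather than ortho to a 3,5-dimethylpiperazin-1-yl group. The earlier step gives no size to lean on. The step from compound 3 to compound 4 in this assay is therefore expected to be a 1.4-fold higher number from compound 3 to compound 4 (0.16 log units; within the scatter), within the scatter. Compound 4 is accordingly estimated at 100 ug/mL, between 30 ug/mL and 300 ug/mL.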

Compound 4, half-maximal inhibitory concentration: > 500 ug/mL
Compound 4 gave a limit, no number; the forecaster's own chance of this, stated with the estimate: 20%; middle value at least 5.0-fold (0.69 log units) away from the limit.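

With a 3-aminopiperidin-1-yl group on the shared core, trifluoromethyl in place of methoxy made an at least 7.2-fold higher number from compound 3 to compound 4 (0.86 log units; beyond the scatter) in this assay. Going by these compounds alone, the same change with a 3,5-dimethylpiperazin-1-yl group, and the swap of these two groups with trifluoromethyl in place, cannot be read, because both partners in each pair sit at the limit: the limit of > 500 ug/mL in this assay, at which 3 of the 4 values shown sit. The change therefore has a readable size with only one of the two groups, so these compounds do not show whether that size carries over to the other, and the full size of the step also stays unknown.

The compounds shown leave open how a methyl or a chloro group in place of methoxy would read in this assay. They also leave open how an unsubstituted piperazin-1-yl group would read there.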